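The source may hold more compounds than are shown below. What is called first, only, known or untested is meant among the compounds shown, and "the series" means these compounds.

Measured so far:
Compound 1 `Nc1nc(-c2ccc(Cl)cc2)cc(-c2ccccc2O)n1` gives > 74700 nM in an ADME assay on MT4 cells (Homo sapiens) for cytotoxicity, read by MTT assay, with a stated time of 5 days (on this read-out lower numbers stand for higher toxicity in this test and higher numbers for lower toxicity in this test), which is a limit of the test rather than a number.
Compound 2 `Cc1cccc(-c2cc(-c3ccccc3O)nc(N)n2)c1` gives 13000 nM in this assay.

Among the measured compounds shown here, compound 2 thus holds the only real number among the two values shown. For the measured compounds named here, the one measured step, an at least 5.7-fold lower number from compound 1 to compound 2 (0.75 log units; beyond the scatter), carried the read-out from the limit down to that number. Compound 3 `Nc1nc(-c2cccc(Cl)c2)cc(-c2ccccc2O)n1` differs from compound 2 by chloro in place of methyl on an aromatic carbon. Going by the values given here, no measured step covers this swap, and the known step exchanged a different group, so it offers little guidance. A step of a 1.5-fold higher number from compound 2 to compound 3 (0.19 log units; within the scatter) is expected, and compound 3 is estimated at 20000 nM, within 7000 nM to 74700 nM.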

Compound 3, half-maximal cytotoxic concentration: > 125000 nM
Compound 3: only a limit was reported; the forecaster's own chance of this, stated with the estimate: 25%; middle value at least 6.2-fold (0.79 log units) away from the limit.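

Putting chloro in place of methyl on this aromatic carbon gives an at least 9.6-fold higher number from compound 2 to compound 3 (0.98 log units; beyond the scatter) in this assay, so the lower number goes with the methyl group and not with the position alone. The reading for compound 3 is a limit of the test, not a number: the limit of > 125000 nM in this assay, at which 1 of the 3 values shown sits.
Compound 1 and compound 3 both carry limits, and the step between them cannot be read. From the compounds shown here alone, how an ethyl, a methoxy or an amine on the same carbon would read remains open, and so does any ranking of the two chloro compounds.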